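The compounds below may be only part of what the source reports. "The series", "measured", "known", "first", "only" and "open" are said of these compounds alone.

Measured so far:
compound 1 `Cc1ccc(C(CCN2CCN(c3ccccc3)CC2)OC(N)=O)cc1` — 100%
compound 2 `NC(=O)OC(CCN1CCN(c2ccccc2)CC1)c1cccc(Cl)c1` — 100%

In a functional assay on the whole organism for inhibition, with Mus musculus as the target, in the writhing test, with a stated time of 1 h, at a dose of 10 mg/kg by the intraperitoneal route (on this read-out lower numbers stand for less inhibition and higher numbers for more inhibition at the one dose given (going by the name of the read-out)), compound 1 gives 100%, and in the same test compound 2 gives 100%. Going by the values given here, compound 2 therefore stands level with compound 1 at the digits reported; the one step that joins them, no change at the digits printed from compound 1 to compound 2 (within the scatter), is within the scatter. Compound 3 `NC(=O)OC(CCN1CCN(c2ccccc2)CC1)c1ccc(F)cc1` has not yet been tested. It differs from compound 2 by 4-fluorophenyl in place of 3-chlorophenyl on a saturated chain carbon bound to an oxygen next to a carbonyl group and a saturated chain carbon. Among the compounds with values here, only the step from compound 1 to compound 2 bears on this change, and that step showed no movement beyond the scatter despite a change of the same kind at the same place. Because of no change at the digits printed from compound 1 to compound 2 (within the scatter) the expected step of a number 5 percentage points lower from compound 2 to compound 3 (within the scatter) is no change beyond the scatter. Compound 3 is thus estimated to give about 95%, with a range from 75% to 100%.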

Compound 3, a percentage reported as inhibition, in the whole organism at one dose (the size of the read-out at that dose, not a potency): 99%
The estimate for compound 3 lay 4 percentage points below the measured number; the range from low to high includes it.
By their numbers in this assay, from the lowest: compounds 3, 1 and 2 (each within the scatter of the next).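

In this assay, 4-fluorophenyl in place of 3-chlorophenyl on a saturated chain carbon bound to an oxygen next to a carbonyl group and a saturated chain carbon gives a number 1 percentage points lower from compound 2 to compound 3 (within the scatter), and fluoro in place of methyl on an aromatic carbon gives a number 1 percentage points lower from compound 1 to compound 3 (within the scatter). The earlier pair covered only 4-methylphenyl and 3-chlorophenyl at this place, and 4-fluorophenyl now joins them with no separation beyond the scatter at this single dose. No measurement shown accounts for this level result.

The three values at one dose leave open how these compounds compare in potency. Also open, on these data alone, is whether a carboxylic acid or an amine in place of the fluoro, or a longer chain in place of the 4-fluorophenyl, would keep the read-out level.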